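A few compounds are considered here, and "the series" means these few. Any claim that something is new, unique, unknown or untested is made for them only; others in the source may bear on it.

Compound 2 `Nc1ccc(-c2cc(=O)c3c(N)c(F)c(O)c(F)c3o2)cc1F`, compound 1 `Cc1c(F)c(N)c2c(=O)cc(-c3ccc(N)c(F)c3)oc2c1F` and compound 3 `Nc1ccc(-c2cc(=O)c3c(N)c(F)c(C(=O)O)c(F)c3o2)cc1F` share one core and differ at a single aromatic carbon. In a functional assay on HeLa cells (Homo sapiens) for cytotoxicity, read by neutral red uptake, with a stated time of 3 days (on this read-out lower numbers stand for stronger inhibition and higher numbers for weaker inhibition), compound 1 gives only the assay limit of > 100000 nM. Compound 2 likewise reaches no more than the limit of > 100000 nM. Compound 3 also stops at the limit of > 100000 nM. So (the limit of > 100000 nM in this assay, at which 3 of the 3 values shown sit), and the steps a step that the two limits leave unreadable from compound 1 to compound 2, a step that the two limits leave unreadable from compound 1 to compound 3 and a step that the two limits leave unreadable from compound 2 to compound 3 cannot be sized. Compound 4 `CN(C)CC(=O)OCc1c(F)c(N)c2c(=O)cc(-c3ccc(N)c(F)c3)oc2c1F` differs from compound 2 by ((((dimethylamino)methyl)carbonyl)oxy)methyl in place of hydroxy on an aromatic carbon. Going by the values given here, no measured step of readable size bears on this change, so no shift beyond the scatter is expected. Compound 4 is therefore estimated at 150000 nM, between 50000 nM and 500000 nM. That estimate means a step that the limit leaves unreadable from compound 2 to compound 4.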

Compound 4, half-maximal inhibitory concentration: 9200 nM
Estimate against measurement, compound 4: 16-fold (1.21 log units) above; measured number outside the range, below it.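

In this assay compound 4 is the only compound shown with a number inside the assay's range, so a change at this aromatic carbon can move the read-out. ((((Dimethylamino)methyl)carbonyl)oxy)methyl gives an at least 10-fold lower number from compound 2 to compound 4 (1.03 log units; beyond the scatter) and an at least 10-fold lower number from compound 3 to compound 4 (1.03 log units; beyond the scatter), while (((dimethylamino)methyl)carbonyl)oxy on the methyl group gives an at least 10-fold lower number from compound 1 to compound 4 (1.03 log units; beyond the scatter). These sizes are bounds only, since one end of each step is a limit: the limit of > 100000 nM in this assay, at which 3 of the 4 values shown sit.

The compounds shown leave open whether the dimethylamino group or the carbonyl carries this shift. They also do not show whether a morpholine or a longer chain at this carbon would give a similar step.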